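From 4-propylphenyl to 3-bromophenyl on the amide

The compounds below may be only part of what the source reports. "The series", "measured", "known", "first", "only" and "open" are said of these compounds alone.

In a functional assay on MGC-803 cells (Homo sapiens) for inhibition, read by MTT assay, with a stated time of 72 h (on this read-out lower numbers stand for stronger inhibition and higher numbers for weaker inhibition), compound 1 `CCCc1ccc(NC(=O)C2CCN(C/C=C/c3ccccc3)CC2)cc1` gives 5210 nM. It shares the low end of the three measured numbers with compound 2 `O=C(Nc1cccc(C(F)(F)F)c1)C1CCN(C/C=C/c2ccccc2)CC1` at 9590 nM, the two lying within the scatter of each other. Compound 3 `O=C(Nc1cccc(Cl)c1)C1CCN(C/C=C/c2ccccc2)CC1`, at 11300 nM, stands beyond the scatter from compound 1.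

Compound 4 `O=C(Nc1cccc(Br)c1)C1CCN(C/C=C/c2ccccc2)CC1` has not yet been measured. It departs from compound 1 by one change: 3-bromophenyl in place of 4-propylphenyl on an amide-type nitrogen. In words, this is 3-bromophenyl in place of 4-propylphenyl on an amide-type nitrogen. Within the data shown here, two measured steps bear on it. The closest is a 2.2-fold higher number from compound 1 to compound 3 (0.34 log units; beyond the scatter), a modest step for the same kind of exchange, with 3-chlorophenyl entering. The other is a 1.2-fold higher number from compound 2 to compound 3 (0.07 log units; within the scatter), which shows chloro and trifluoromethyl on an aromatic carbon giving numbers within the scatter of each other. Among the measured compounds shown here, no bromo compound has been measured, so this assay is expected to show a modest rise of similar size. The expected step is a 1.9-fold higher number from compound 1 to compound 4 (0.28 log units; within the scatter). Compound 4 is therefore estimated at 10000 nM, with an expected range of 5500 nM to 18000 nM.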

Compound 4, half-maximal inhibitory concentration: 9110 nM
The estimate for compound 4 lay 1.1-fold (0.04 log units) above the measured number; the measured number falls inside the stated range.
By their numbers in this assay, from the lowest: compounds 1, 4, 2 and 3 (each within the scatter of the next, the first and the last beyond it).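

In this assay, bromo on this aromatic carbon shows no separation from either group already tested there, with a 1.2-fold lower number from compound 3 to compound 4 (0.09 log units; within the scatter) and a 1.1-fold lower number from compound 2 to compound 4 (0.02 log units; within the scatter), so the bromo, chloro and trifluoromethyl compounds cannot be told apart. The exchange of 4-propylphenyl for 3-bromophenyl gives a 1.7-fold higher number from compound 1 to compound 4 (0.24 log units; within the scatter), while the closely related exchange with 3-chlorophenyl gave a 2.2-fold higher number from compound 1 to compound 3 (0.34 log units; beyond the scatter), so the advantage of the propyl compound over this set of aryl amides is slight and holds beyond the scatter for only one of the three. Nothing measured here accounts for these numbers.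

The compounds shown leave open whether an amine or a carboxylic acid on this phenyl ring would shift the number beyond the scatter. They also leave open whether a butyl chain in place of propyl would improve on compound 1 at 5210 nM.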